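Pyridin-2-yl Replaces 4-Fluorophenyl on the Ring Nitrogen

This account rests on a few compounds, and the source may have more. Where it says the series, first, only, none or still open, it means among the compounds named here.

In an assay on CHO cells for displacement of a labelled ligand from adenosine receptor A1 (Homo sapiens) (a lower number here means tighter binding, a higher number weaker binding), compound 2 `Nc1scc(CN2CCN(c3ccc(F)cc3)CC2)c1C(=O)c1ccc(Cl)cc1` gives 1 nM, level with compound 3 `Nc1scc(CN2CCN(c3ccc(C(F)(F)F)cc3)CC2)c1C(=O)c1ccc(Cl)cc1` at 1 nM, and the two sit together as the lowest of the three numbers, while compound 1 `Nc1scc(CN2CCN(C3CCCCC3)CC2)c1C(=O)c1ccc(Cl)cc1` at 1.1 nM lies within the scatter of both. Compound 4 `Nc1scc(CN2CCN(c3ccccn3)CC2)c1C(=O)c1ccc(Cl)cc1` carries pyridin-2-yl in place of 4-fluorophenyl on an amine nitrogen in a ring. Among the measured compounds shown here, two measured steps bear on this site: a 1.1-fold lower number from compound 1 to compound 2 (0.04 log units; within the scatter) and no change at the digits printed from compound 2 to compound 3 (within the scatter), both within the scatter, so changing the group on that ring nitrogen has so far shifted nothing. For the measured compounds named here, no measured pair tests a ring nitrogen within that group. Compound 4 is therefore expected to come out near 1.3 nM, with a range from 0.5 nM to 3.5 nM. The expected step is a 1.3-fold higher number from compound 2 to compound 4 (0.11 log units; within the scatter), none beyond the scatter.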

Compound 4, dissociation constant: 1.2 nM
The estimate for compound 4 lay 1.1-fold (0.03 log units) above the measured number, and the stated range covers the measured number.
By their numbers in this assay, from the lowest: compounds 2, 3, 1 and 4 (each within the scatter of the next).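

In this assay, among the compounds shown here, the steps of a 1.2-fold higher number from compound 2 to compound 4 (0.08 log units; within the scatter) and a 1.2-fold higher number from compound 3 to compound 4 (0.08 log units; within the scatter) and a 1.1-fold higher number from compound 1 to compound 4 (0.04 log units; within the scatter) all stay within the scatter, and these are the first measured pairs in which the group on the amine nitrogen in a ring carries a ring nitrogen. Pyridin-2-yl, with its hetero atom and hydrogen-bond acceptor, therefore joins cyclohexyl and the two substituted phenyl groups with no step beyond the scatter at this position. Nothing here gives a reason for this result. Still open, going by these compounds, is whether pyridin-4-yl, or a phenyl group bearing a carboxylic acid, would give a step beyond the scatter at this position.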